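Adding a bromine to the triazole benzyl group

The source may report more compounds than this note shows. Statements on the series, on what has been measured and on what is new or still open speak of the compounds shown alone.

Three chalcone-type compounds have been measured in a functional assay on MCF7 cells (Homo sapiens) for inhibition, read by MTT assay, with a stated time of 48 h, tested at 10 uM; on this read-out lower numbers stand for less inhibition of growth and higher numbers for more inhibition of growth at the one concentration tested. Compound 1 `C#CCOc1ccc(/C=C/C(=O)c2ccc(OC)cc2)cc1` gives 32%. Compound 2 `C#CCOc1ccc(/C=C/C(=O)c2ccc([N+](=O)[O-])cc2)cc1` carries a nitro group where compound 1 carries a methoxy group; in this assay compound 2 gives 44%, and the step of a number 12 percentage points higher from compound 1 to compound 2 (beyond the scatter) is the only one in this set that goes beyond the scatter. Compound 3 `O=C(/C=C/c1ccc(OCc2cn(Cc3ccccc3)nn2)cc1)c1ccc(Br)cc1`, with a benzyl-bearing triazole on the ether side and a bromine on the ketone-side ring, gives 34% in this assay; its number lies between those of compound 1 and compound 2, and neither gap is beyond the scatter.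

Compound 4 `O=C(/C=C/c1ccc(OCc2cn(Cc3cccc(Br)c3)nn2)cc1)c1ccc(Br)cc1` differs from compound 3 in one place: bromo in place of hydrogen on an aromatic carbon. For the measured compounds named here, no measured step touches the benzyl ring on the triazole, so the only step available, from compound 1 to compound 2, changes a group on a different ring and offers no direct guide. In this assay the step of a number 2 percentage points higher from compound 3 to compound 4 (within the scatter) is therefore expected to stay within the scatter. On that basis compound 4 is estimated to give about 36% in this assay, most likely between 22% and 52%.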

Compound 4, percent growth inhibition at one concentration: 36%
Estimate against measurement, compound 4: no gap at the digits printed; the measured number falls inside the stated range.
By their numbers in this assay, from the lowest: compounds 1, 3, 4 and 2 (each within the scatter of the next, the first and the last beyond it).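

For the compounds shown here, compound 4 gives the first direct look at the benzyl ring on the triazole. In this assay, going from phenyl to 3-bromophenyl at this position gives a number 2 percentage points higher from compound 3 to compound 4 (within the scatter), so adding this one bromine on an aromatic carbon, meta to a large group, does not separate the two compounds on this read-out at the one concentration tested. Going by these compounds alone, the only step beyond the scatter so far, a number 12 percentage points higher from compound 1 to compound 2 (beyond the scatter), lies on a different ring and says nothing about this one, and no measurement at hand offers an explanation for the result on the benzyl ring.

As far as these compounds go, what other groups would do on this ring stays open, for example an amine or a carboxylic acid, as does a longer chain in place of the benzyl group or a bromine elsewhere on the ring. From the compounds shown here alone, it is also open whether a nitro group, in place of the bromine on the ketone-side ring of compound 3, would give a step of the size seen with the nitro group in compound 2.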